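Pipecolyl amide at the benzylamine of the indazole sulfonamide series

A few compounds are considered here, and "the series" means these few. Any claim that something is new, unique, unknown or untested is made for them only; others in the source may bear on it.

Measured:
compound 1 `COc1cccc2c1c(NS(=O)(=O)c1ccc(Cl)s1)nn2Cc1cccc(CNC(=O)C2CCOCC2)c1`: 501 nM
compound 2 `COc1cccc2c1c(NS(=O)(=O)c1ccc(Cl)s1)nn2Cc1cccc(CNC(=O)C(C)(C)N)c1`: 141 nM

Compound 2 stands lowest of the two numbers in an assay on isolated protein (blood) for antagonist activity at C-C chemokine receptor type 4 (Homo sapiens), read by flow cytometry, with a stated time of 30 min; on this read-out lower numbers stand for tighter binding and higher numbers for weaker binding; compound 1 sits at a 3.6-fold lower number from compound 1 to compound 2 (0.55 log units; beyond the scatter) above it. Compound 3 `COc1cccc2c1c(NS(=O)(=O)c1ccc(Cl)s1)nn2Cc1cccc(CNC(=O)[C@@H]2CCCCN2)c1` is not yet measured. Its change from compound 2 is piperidin-2-yl in place of 1-amino-1-methylethyl on a carbonyl carbon. Within the data shown here, only the step from compound 1 to compound 2 touches the same carbonyl carbon, where a nitrogen-bearing group replaced oxan-4-yl. Compound 3 keeps a nitrogen-bearing group there, so in this assay the expected step is a 1.1-fold higher number from compound 2 to compound 3 (0.05 log units; within the scatter), none beyond the scatter. Compound 3 is expected near 160 nM, between 60 nM and 450 nM.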

Compound 3, dissociation constant in the C-C chemokine receptor type 4 assay: 126 nM
For compound 3 the middle estimate is 1.3-fold (0.10 log units) above the measured one; low and high end bracket the measured number.
By their numbers in the C-C chemokine receptor type 4 assay, from the lowest: compounds 3 and 2 (each within the scatter of the next); then compound 1.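

On the carbonyl carbon, the C-C chemokine receptor type 4 assay does not separate piperidin-2-yl in compound 3, at 126 nM, from 1-amino-1-methylethyl in compound 2, at 141 nM (a 1.1-fold lower number from compound 2 to compound 3 (0.05 log units; within the scatter)), while piperidin-2-yl also stands apart from oxan-4-yl in compound 1, at 501 nM (a 4.0-fold lower number from compound 1 to compound 3 (0.60 log units; beyond the scatter)). Two nitrogen-bearing groups, one open-chain and one ringed, now both lie beyond the scatter from oxan-4-yl. No evidence is at hand to account for these steps.

In a physicochemical assay for acid dissociation, compound 2 gives "not determined" (no result reported) and compound 3 gives "not determined" (no result reported), so no step can be read there. Open, going by these compounds, is how the opposite configuration of piperidin-2-yl, a pyrrolidin-2-yl ring or a carboxylic acid would read on this carbonyl carbon.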